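Flavonol amide series: moving the methoxy group

The source may report more compounds than this note shows. Statements on the series, on what has been measured and on what is new or still open speak of the compounds shown alone.

Measured so far:
compound 1 `O=C(Nc1cccc(-c2oc3cc(-c4ccc(F)cc4)ccc3c(=O)c2O)c1)c1ccc(F)cc1` with 8590 nM
compound 2 `COc1ccc(C(=O)Nc2cccc(-c3oc4cc(-c5ccc(F)cc5)ccc4c(=O)c3O)c2)cc1` with 6250 nM

Both compounds share the same core and differ only in the group at the far end of the amide. In a functional assay on MCF7 cells (Homo sapiens) for antiproliferative activity, read by CCK-8 assay, with a stated time of 72 h (a higher number here means a weaker inhibitor, a lower number a stronger inhibitor), compound 1 gives 8590 nM. In the same assay compound 2 gives 6250 nM. The only step measured so far is a 1.4-fold lower number from compound 1 to compound 2 (0.14 log units; within the scatter), and it falls inside the usual scatter, so compound 2 and compound 1 stand level on the numbers shown; compound 2 cannot be called the stronger of the two.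

Compound 3 `COc1cccc(C(=O)Nc2cccc(-c3oc4cc(-c5ccc(F)cc5)ccc4c(=O)c3O)c2)c1` is the next member. Its change from compound 2 is 3-methoxyphenyl in place of 4-methoxyphenyl on a carbonyl carbon. Among the compounds with values here, no measured step moves a substituent around that ring; the one step in hand only exchanges the group on it, and that step was within the scatter. The expectation is therefore no shift beyond the scatter, in either direction, as a 1.0-fold higher number from compound 2 to compound 3 (0.02 log units; within the scatter). Compound 3 is estimated to give 6500 nM in this assay, with a range from 2500 nM to 17000 nM.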

Compound 3, half-maximal inhibitory concentration: 15300 nM
Estimate against measurement, compound 3: 2.4-fold (0.37 log units) below; measured number inside the range.
By their numbers in this assay, from the lowest: compounds 2, 1 and 3 (each within the scatter of the next, the first and the last beyond it).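

Moving the methoxy group gives the first change in this series that registers beyond the scatter: in this assay, 3-methoxyphenyl in place of 4-methoxyphenyl on the carbonyl carbon gives a modest loss (a 2.4-fold higher number from compound 2 to compound 3 (0.39 log units; beyond the scatter)), whereas exchanging fluoro for methoxy at the 4-position of that ring stayed within it (a 1.4-fold lower number from compound 1 to compound 2 (0.14 log units; within the scatter)). The ring at the far end of the amide therefore responds to where the methoxy sits, although the loss can be read only against the 4-methoxyphenyl compound, since 3-methoxyphenyl in place of 4-fluorophenyl stays within the scatter (a 1.8-fold higher number from compound 1 to compound 3 (0.25 log units; within the scatter)), leaving compound 3 and compound 1 level on these numbers. Nothing available here accounts for the shift in either direction.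

Three amides cannot show whether this sensitivity to placement belongs to methoxy alone or would also appear if the fluoro group were moved in the same way. Also open, as far as these compounds go, is how this ring would tolerate a longer chain such as ethoxy in place of methoxy, or an amine or a carboxylic acid on the same carbon.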